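The compounds below may be only part of what the source reports. "The series", "measured", "known", "first", "only" and "open" are said of these compounds alone.

Measured compounds in a functional assay on HT-29 cells (Homo sapiens) for inhibition, read by MTT assay, with a stated time of 72 h; on this read-out higher numbers stand for weaker inhibition and lower numbers for stronger inhibition:
compound 1 `COc1cc(Oc2cccc(Nc3ccccc3)c2)cc(OC)c1CNCc1ccc(F)cc1` gives 2750 nM;
compound 2 `COc1cc(Oc2cccc(Nc3ccccc3)c2)cc(OC)c1CNCCNC(C)=O` gives 3960 nM;
compound 3 `COc1cc(Oc2cccc(Nc3ccccc3)c2)cc(OC)c1CNCc1ccc(C)cc1` gives 3880 nM.

Compound 1 shows the lowest of these three numbers, yet the steps of a 1.4-fold higher number from compound 1 to compound 2 (0.16 log units; within the scatter) and a 1.4-fold higher number from compound 1 to compound 3 (0.15 log units; within the scatter) both stay within the scatter, so the three compounds cannot be told apart on these data.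

Compound 4 `COc1cc(Oc2cccc(Nc3ccccc3)c2)cc(OC)c1CN[C@H](C)c1ccccc1` is not yet measured. It differs from compound 1 by 1-phenylethyl in place of 4-fluorobenzyl on an amine nitrogen. The two measured steps that alter the same part of the molecule, a 1.4-fold higher number from compound 1 to compound 2 (0.16 log units; within the scatter) and a 1.4-fold higher number from compound 1 to compound 3 (0.15 log units; within the scatter), were both small, whether the aromatic ring was kept or exchanged for a short chain. On that basis the step from compound 1 to compound 4 is expected to be a 1.1-fold higher number from compound 1 to compound 4 (0.04 log units; within the scatter), within the scatter. Compound 4 is therefore estimated at 3000 nM, with a range from 1400 nM to 6500 nM.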

Compound 4, half-maximal inhibitory concentration: 5120 nM
Compound 4: middle estimate off by 1.7-fold (0.23 log units), on the low side, within the range that was stated.
By their numbers in this assay, from the lowest: compounds 1, 3, 2 and 4 (each within the scatter of the next).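

In this assay, going by these compounds alone, a 1.9-fold higher number from compound 1 to compound 4 (0.27 log units; within the scatter) and a 1.3-fold higher number from compound 3 to compound 4 (0.12 log units; within the scatter) and a 1.3-fold higher number from compound 2 to compound 4 (0.11 log units; within the scatter) together show that 1-phenylethyl, the first group here with a defined stereocentre, also cannot be told apart from the other groups on this amine nitrogen. Across these four compounds, no listed change at this position moves the number beyond the scatter. No measurement here accounts for how close the numbers lie.

Still open, on these data alone, is whether a carboxylic acid or a longer chain ending in an amine would leave the number within the scatter. As far as these compounds go, the mirror-image form of 1-phenylethyl is equally open.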